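Naphthalenyl in Place of Trifluoromethylphenyl: Expected Cytotoxicity

This account rests on a few compounds, and the source may have more. Where it says the series, first, only, none or still open, it means among the compounds named here.

Measured so far in an ADME assay on HepG2 cells (Homo sapiens) for cytotoxicity, read by luminescence, CellTiter-Glo and ATP content, with a stated time of 72 h; a higher number here means that more compound is needed for the effect, a lower number that less compound is needed:
compound 1 `COc1ccc(F)cc1CNCCCNc1ccnc2cc(Cc3cccc(C(F)(F)F)c3)ccc12` gives 440 nM
compound 2 `COc1ccc(F)cc1CNCCCNc1ccnc2cc(CC(C)C)ccc12` gives 2900 nM
compound 3 `COc1ccc(F)cc1CNCCCNc1ccnc2cc(-c3ccc(C(F)(F)F)cc3)ccc12` gives 5190 nM

Compound 3 gives the highest number of the three in this assay; the step of a 1.8-fold higher number from compound 2 to compound 3 (0.25 log units; within the scatter) lies within the scatter, whereas a 12-fold higher number from compound 1 to compound 3 (1.07 log units; beyond the scatter) is large. Compound 4 `COc1ccc(F)cc1CNCCCNc1ccnc2cc(-c3cccc4ccccc34)ccc12` differs from compound 3 by naphthalen-1-yl in place of 4-(trifluoromethyl)phenyl on an aromatic carbon. Among the measured compounds shown here, no measured step exchanges one aryl group for another at that position; the nearest guides are a 1.8-fold higher number from compound 2 to compound 3 (0.25 log units; within the scatter), small, and a 6.6-fold higher number from compound 1 to compound 2 (0.82 log units; beyond the scatter), modest. Nothing here points to a shift beyond the scatter. For compound 4 the expected step is a 1.7-fold lower number from compound 3 to compound 4 (0.24 log units; within the scatter). The estimate for compound 4 in this assay is 3000 nM, between 900 nM and 10000 nM.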

Compound 4, half-maximal effective concentration: 16000 nM
For compound 4 the middle estimate is 5.3-fold (0.73 log units) below the measured one, outside the stated range (above it).
By their numbers in this assay, from the lowest: compound 1; then compounds 2 and 3 (each within the scatter of the next); then compound 4.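

In this assay, exchanging one aromatic group for another on this aromatic carbon moves the number beyond the scatter, with a 3.1-fold higher number from compound 3 to compound 4 (0.49 log units; beyond the scatter), although both groups hold the same count of heavy atoms. Naphthalen-1-yl also separates from isobutyl, with a 5.5-fold higher number from compound 2 to compound 4 (0.74 log units; beyond the scatter), which 4-(trifluoromethyl)phenyl did not, and lies further still from 3-(trifluoromethyl)benzyl, with a 36-fold higher number from compound 1 to compound 4 (1.56 log units; beyond the scatter). No measurement at hand explains this rise. On these data alone, whether it follows from the second fused ring or from the absence of trifluoromethyl stays open, as does how naphthalen-2-yl or a phenyl ring carrying an amine would read here.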